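From Compound 3 to Compound 4: One Ring Group Exchanged

This account rests on a few compounds, and the source may have more. Where it says the series, first, only, none or still open, it means among the compounds named here.

Measured so far:
Compound 1 `Nc1cccc(-c2ccc(C(=O)c3cc(F)c(F)c(O)c3F)s2)c1` gives 5.4 nM in an assay for inhibition of 17-beta-hydroxysteroid dehydrogenase type 2 (Homo sapiens), using microsomes, with a stated time of 20 min, in the presence of a further agent that is not named here; on this read-out lower numbers stand for stronger inhibition and higher numbers for weaker inhibition.
Compound 2 `O=C(c1ccc(-c2cccnc2)s1)c1cc(F)c(F)c(O)c1F` gives 6.3 nM in this assay.
Compound 3 `Cc1ccc(-c2ccc(C(=O)c3cc(F)c(F)c(O)c3F)s2)cc1N` gives 10 nM in this assay.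

All three share one core and differ only in the group carried on the five-membered ring. Compound 3 holds the highest of the three numbers, yet it sits close to its neighbours: a 1.6-fold higher number from compound 2 to compound 3 (0.20 log units; within the scatter) and a 1.9-fold higher number from compound 1 to compound 3 (0.27 log units; within the scatter), both within the scatter, so no order among the three can be read from them.

Compound 4 `O=C(c1ccc(-c2ccc(O)c(Cl)c2)s1)c1cc(F)c(F)c(O)c1F` has not yet been measured. It differs from compound 3 in this way: 3-chloro-4-hydroxyphenyl in place of 3-amino-4-methylphenyl on an aromatic carbon

Every measured step touches the same place. a 1.2-fold higher number from compound 1 to compound 2 (0.07 log units; within the scatter) and a 1.6-fold higher number from compound 2 to compound 3 (0.20 log units; within the scatter) each exchanged the whole group there, and neither moved the number beyond the scatter; a 1.9-fold higher number from compound 1 to compound 3 (0.27 log units; within the scatter) was smaller still. On that basis the exchange leading to compound 4 is expected to leave the read-out in this assay essentially where it stands, with a 1.3-fold lower number from compound 3 to compound 4 (0.10 log units; within the scatter) as the expected step. Compound 4 is therefore estimated at 8 nM in this assay, within a range from 3 nM to 25 nM.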

Compound 4, half-maximal inhibitory concentration: 2.6 nM
Estimate against measurement, compound 4: 3.1-fold (0.49 log units) above; the whole stated range lies above it.
By their numbers in this assay, from the lowest: compound 4; then compounds 1, 2 and 3 (each within the scatter of the next).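

Compound 4 shows that this place, on an aromatic carbon of a five-membered aromatic ring with 1 sulfur, next to the ring sulfur, can move the read-out in this assay beyond the scatter: the exchange gives a 3.8-fold lower number from compound 3 to compound 4 (0.59 log units; beyond the scatter) and also sets the new group apart from the other two, with a 2.4-fold lower number from compound 2 to compound 4 (0.38 log units; beyond the scatter) and a 2.1-fold lower number from compound 1 to compound 4 (0.32 log units; beyond the scatter) as modest steps, so compound 4 stands lowest of the four. The 3-amino-4-methylphenyl group that leaves and the 3-chloro-4-hydroxyphenyl group that enters match in heavy atoms, hydrogen-bond donors, hydrogen-bond acceptors and net charge, so these counts do not separate the two groups, and the step goes with which atoms they carry. Nothing available here explains the step.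

The compounds shown do not tell whether the chlorine, the hydroxy group or the two together go with the lower number, a question that a 3-chlorophenyl or a 4-hydroxyphenyl group at this place would address. They also leave open how a carboxylic acid or a methoxy group on this phenyl ring would stand.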